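Moving the Methyl Group on the Sulfonamide Anilide

A few compounds are considered here, and "the series" means these few. Any claim that something is new, unique, unknown or untested is made for them only; others in the source may bear on it.

Measured so far:
Compound 1, `CCCCCc1ccc(NS(=O)(=O)c2ccc(N3CCNC3=O)cc2)cc1`, gives 990 nM in a functional assay on HT-29 cells (Homo sapiens) for antiproliferative activity, read by sulforhodamine B assay, with a stated time of 48 h; on this read-out higher numbers stand for weaker inhibition and lower numbers for stronger inhibition.
Compound 2, `Cc1ccccc1NS(=O)(=O)c1ccc(N2CCNC2=O)cc1`, gives 200 nM in this assay.
Compound 3, `CCCCCCOc1ccc(NS(=O)(=O)c2ccc(N3CCNC3=O)cc2)cc1`, reaches only a limit of this assay, > 1000 nM, and no number is known for it.

Compound 2 has the lowest number of the two numbers shown; the nearest is compound 1, whose number is higher by a margin beyond the usual scatter. Among the compounds with values here, the only single-point step among the measured compounds runs from compound 1 to compound 3, a number no lower from compound 1 to compound 3 (the limit leaves the size open), where the result rests on (the limit of > 1000 nM in this assay, at which 1 of the 3 values shown sits).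

Compound 4, `Cc1cccc(NS(=O)(=O)c2ccc(N3CCNC3=O)cc2)c1`, is the compound to be measured. It differs from compound 2 by 3-methylphenyl in place of 2-methylphenyl on a sulfonamide nitrogen. Within the data shown here, the step from compound 1 to compound 3 changes a group on an aromatic carbon of the other ring and says nothing about the sulfonamide nitrogen side, so no measured step bears directly on this change. The expectation therefore rests on the shared core alone: a modest move from compound 2, with the direction open, is expected, most likely a somewhat weaker result, that is a higher number in this assay. Compound 4 is estimated at 400 nM, within 130 nM to 1200 nM. The step this estimate means is a 2.0-fold higher number from compound 2 to compound 4 (0.30 log units; within the scatter), which is expected to sit near the edge of the scatter.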

Compound 4, half-maximal inhibitory concentration: 110 nM
Compound 4: the middle estimate sits 3.6-fold (0.56 log units) above what was measured; measured number below the stated range.
By their numbers in this assay, from the lowest: compounds 4 and 2 (each within the scatter of the next); then compound 1. At a limit, above all of these: compound 3.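

The swap of 2-methylphenyl for 3-methylphenyl on the sulfonamide nitrogen is the first step shown that changes the methyl-bearing phenyl group, and in this assay it is a 1.8-fold lower number from compound 2 to compound 4 (0.26 log units; within the scatter). Compound 2 and compound 4 have the same atoms joined differently, so this pair isolates where the methyl group sits on the phenyl ring, and within the usual scatter of repeated measurements the two cannot be told apart. For this one pair, then, the assay reads no real difference between the two methylphenyl groups, although a single pair cannot show how far that holds, and nothing in the data at hand explains why the two read alike.

Still open, going by these compounds, is what happens when the methyl group itself gives way to another group at either of these two places, such as a chlorine atom, a methoxy group or a carboxylic acid. Also open, on these data alone, is whether a phenyl ring carrying two methyl groups, or an amine on the ring, would stay within the same range in this antiproliferative test.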